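Chloro for hydrogen on the benzyl of compound 3

The compounds below may be only part of what the source reports. "The series", "measured", "known", "first", "only" and "open" are said of these compounds alone.

Measured in an in vitro functional assay on HEK285-7 cells for antagonist activity at prostaglandin D2 receptor 2 (Homo sapiens), read by BRET and beta-arrestin recruitment; a higher number here means a larger maximal response, a lower number a smaller maximal response:
compound 1, `COc1ccc(-c2nc(Nc3ccccc3)sc2CC(=O)O)cc1`: > 70%
compound 2, `O=C(O)Cc1sc(-c2ccccc2)nc1-c1ccc(F)cc1`: > 70%
compound 3, `O=C(O)Cc1sc(Cc2ccccc2)nc1-c1ccc(Cl)cc1`: > 70%

The value given for compound 1 is a limit of this assay, not a number. The same holds for compound 2, whose value is a limit. Compound 3 also stands at a limit in this assay, so its maximal response is not resolved as a number; it sits at the limit of > 70% in this assay, at which 3 of the 3 values shown sit. Going by the values given here, no pair of measured compounds differs in one place, so no measured step can be read from this set, and nothing beyond the common limit separates the three compounds.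

The unmeasured compound 4, `O=C(O)Cc1sc(Cc2ccc(Cl)cc2)nc1-c1ccc(Cl)cc1`, differs from compound 3 in one place:

chloro in place of hydrogen on an aromatic carbon

The change is small, with chloro in place of hydrogen on an aromatic carbon, and compound 3 already sits at the limit, so the step expected in this assay is none beyond the scatter, or at most a small one in either direction. The step from compound 3 to compound 4 is estimated as a step that the limit leaves unreadable from compound 3 to compound 4, with the position of compound 3 at the limit of > 70% in this assay, at which 3 of the 3 values shown sit, as the only reference. For compound 4 the expected maximal response is 85%, between 70% and 100%, most likely reported again as a limit.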

Compound 4, largest response reached (reported as efficacy), in percent of the reference or control that the assay uses: > 70%
Compound 4: no number, only a limit; the forecaster's own chance of this, stated with the estimate: 85%; the middle value is on the limit's open side.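

No step can be read from compound 3 to compound 4 in this assay, because both compounds stand at a limit rather than a number: the limit of > 70% in this assay, at which 4 of the 4 values shown sit.

The compounds shown leave open how large the maximal response of any of them is, and so whether benzyl to 4-chlorobenzyl changes it at all.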